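Amine replacement on the shared core: compound 1 to compound 4

A few compounds are considered here, and "the series" means these few. Any claim that something is new, unique, unknown or untested is made for them only; others in the source may bear on it.

Of the compounds shown here, three with the shared core have been measured in an assay on cell membranes for displacement of a labelled ligand from corticotropin-releasing factor receptor 1 (Rattus norvegicus); on this read-out higher numbers stand for weaker inhibition and lower numbers for stronger inhibition. Compound 1 `CCOCC(COCC)Nc1nc(C)nc2c(-c3ccc(OC)cc3C)c(C)nn12` gives 19.3 nM, the highest number of the three. Compound 2 `CCC(CC)Nc1nc(C)nc2c(-c3cc(OC)c(OC)cc3Br)c(C)nn12` gives 6.08 nM, and compound 3 `C=CCN(CC=C)c1nc(C)nc2c(-c3c(C)cc(OC)cc3OC)c(C)nn12` gives 1 nM. Both gaps from compound 1 lie beyond the scatter, so compound 1 is the weakest binder of the set as it stands; the aryl group differs between all three, so the amine change is not isolated in these numbers.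

Compound 4 `CCCN(CCC#N)c1nc(C)nc2c(-c3ccc(OC)cc3C)c(C)nn12` keeps the aryl group and core of compound 1 and differs only at the amine: (2-cyanoethyl)(propyl)amino in place of (2-ethoxy-1-(ethoxymethyl)ethyl)amino on an aromatic carbon. The group that enters carries no hydrogen-bond donor, as in compound 3, which gave 1 nM, whereas compound 1 and compound 2, each with a donor on the amine, gave the two higher numbers. Among the measured compounds shown here, no pair measured here differs in the amine alone.

The expectation is a move to a lower number, beyond the scatter, with compound 4 estimated at 5 nM (range 1.5 nM to 18 nM); the expected step is a 3.9-fold lower number from compound 1 to compound 4 (0.59 log units; beyond the scatter).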

Compound 4, half-maximal inhibitory concentration: 2.16 nM
The estimate for compound 4 lay 2.3-fold (0.36 log units) above the measured number, within the range that was stated.
By their numbers in this assay, from the lowest: compound 3; then compound 4; then compound 2; then compound 1.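

Among the compounds shown here, with the aryl group and the shared core held fixed, (2-cyanoethyl)(propyl)amino in place of (2-ethoxy-1-(ethoxymethyl)ethyl)amino gives, in this assay, an 8.9-fold lower number from compound 1 to compound 4 (0.95 log units; beyond the scatter), the first step that isolates a change at this position. On this aryl group, the position therefore accepts a tertiary amine with no hydrogen-bond donor and no ether oxygen, and the read-out responds to the amine alone, beyond the scatter. The swap alters the donor, the ether oxygens, the branching and the nitrile together, so this single step does not assign the change to any one of them, and no measurement available here bears on its cause.

Open, from the compounds shown here alone, is whether dipropylamino, with a plain propyl chain in place of the 2-cyanoethyl chain, would keep the number near that of compound 4 on the same aryl group, which would show whether the nitrile contributes to this step. Also open is whether a step of this size carries over to the aryl groups of compound 2 and compound 3, since no pair shown holds either of those aryl groups fixed.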